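A few compounds are considered here, and "the series" means these few. Any claim that something is new, unique, unknown or untested is made for them only; others in the source may bear on it.

Measured so far in a functional assay on A549 cells (Homo sapiens) for antiproliferative activity, read by MTT assay, with a stated time of 24 h; a lower number here means a stronger inhibitor, a higher number a weaker inhibitor:
compound 1 `COc1ccc(C(=O)/C=C/c2cc(-c3ccc(OC)c(OC)c3)n3nc(-c4ccccc4)cc3n2)cc1`: 11900 nM
compound 2 `COc1ccc(-c2cc(/C=C/C(=O)c3ccccc3)nc3cc(-c4ccccc4)nn23)cc1OC`: 10700 nM

Compound 2 stands at the lower of these two numbers, but the step of a 1.1-fold lower number from compound 1 to compound 2 (0.05 log units; within the scatter) lies within the scatter, so the two compounds cannot be separated. Compound 3 `COc1ccc(/C=C/C(=O)c2cc(-c3ccc(OC)c(OC)c3)n3nc(-c4ccccc4)cc3n2)cc1` carries (2-(4-methoxyphenyl)ethenyl)carbonyl in place of 2-benzoylethenyl on an aromatic carbon. Going by the values given here, the one measured step bears only on the methoxy part of this change, and it was within the scatter; the changed order of the carbonyl and the double bonds along the chain has no measured counterpart. No step beyond the scatter is therefore expected, as a 1.0-fold higher number from compound 2 to compound 3 (0.01 log units; within the scatter). Compound 3 is estimated at 11000 nM, within 4500 nM to 27000 nM.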

Compound 3, half-maximal inhibitory concentration: 19300 nM
Compound 3: the middle estimate sits 1.8-fold (0.24 log units) below what was measured; measured number inside the range.
By their numbers in this assay, from the lowest: compounds 2, 1 and 3 (each within the scatter of the next).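

Reversing the order of the carbonyl and the double bond along the chain now has measured counterparts (a 1.8-fold higher number from compound 2 to compound 3 (0.26 log units; within the scatter)), and the same holds where both chains carry the 4-methoxyphenyl group (a 1.6-fold higher number from compound 1 to compound 3 (0.21 log units; within the scatter)). Both steps lie within the scatter, so in this assay neither chain order can be separated from the other at this position. No measurement is available here to explain these numbers. Going by these compounds, what stays open is whether a different group at this position, such as an amine or a carboxylic acid in place of the chain, would give a step beyond the scatter.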